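The source may report more compounds than this note shows. Statements on the series, on what has been measured and on what is new or still open speak of the compounds shown alone.

In a functional assay on SiHa cells (Homo sapiens) for inhibition (on this read-out lower numbers stand for stronger inhibition and higher numbers for weaker inhibition), compound 2 `COc1cc(/C=C/C(=O)c2cccc(N)c2)ccc1O` gives 12.3 ug/mL, and compound 1 `COc1cc(/C=C/C(=O)c2cccc(NC(=O)c3cccs3)c2)ccc1O` gives 6.57 ug/mL. Within the data shown here, these are the only two numbers so far and they lie within the scatter of each other, so compound 2 holds no firm rank in this assay.

The next compound is compound 3 `CCCC(=O)Nc1cccc(C(=O)/C=C/c2ccc(O)c(OC)c2)c1`, which differs from compound 2 as follows: propylcarbonyl in place of hydrogen on a nitrogen on an aromatic ring. In words, propylcarbonyl stands in place of hydrogen on a nitrogen on an aromatic ring, so amino becomes (propylcarbonyl)amino.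

Among the measured compounds shown here, only one measured step bears on this change, at the same nitrogen, where compound 1 carries (thiophen-2-yl)carbonyl: a 1.9-fold higher number from compound 1 to compound 2 (0.27 log units; within the scatter). That single pair involves a different group and stays within the scatter, so it offers only a weak expectation that a carbonyl-bearing group on this nitrogen gives a lower number than hydrogen. No change beyond the scatter is therefore expected.

The estimated step is a 1.4-fold lower number from compound 2 to compound 3 (0.16 log units; within the scatter). For compound 3 the expected value is 8.5 ug/mL, with an estimated range of 3.5 ug/mL to 20 ug/mL.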

Compound 3, half-maximal inhibitory concentration: 3.94 ug/mL
Estimate against measurement, compound 3: 2.2-fold (0.33 log units) above; the measured number falls inside the stated range.
By their numbers in this assay, from the lowest: compounds 3, 1 and 2 (each within the scatter of the next, the first and the last beyond it).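

Placing propylcarbonyl on the nitrogen gives the first step in this series beyond the scatter in this assay (a 3.1-fold lower number from compound 2 to compound 3 (0.49 log units; beyond the scatter)), so a change at this nitrogen can move the number measurably. The earlier pair at the same nitrogen, with (thiophen-2-yl)carbonyl, stayed within the scatter (a 1.9-fold higher number from compound 1 to compound 2 (0.27 log units; within the scatter)), so compound 1 does not share this firm separation from the free amino compound. The two carbonyl-bearing groups themselves cannot be told apart (a 1.7-fold lower number from compound 1 to compound 3 (0.22 log units; within the scatter)), which means that the change from thiophen-2-yl to propyl on the carbonyl carbon has no firm effect here and that a ring on this carbonyl carbon is not needed for a number in this range. Nothing at hand explains the step.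

Three compounds leave open how the number follows the size and shape of the group on this carbonyl carbon, for example with a methyl, a longer chain such as pentyl, or a phenyl ring. Going by these compounds, it is also open whether the carbonyl itself matters, which a plain alkyl group or a sulfonyl group on the same nitrogen would test.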